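Compound 1 to Compound 4: Expected Cytotoxicity Read-out

The compounds below may be only part of what the source reports. "The series", "measured", "known", "first", "only" and "open" are said of these compounds alone.

Measured compounds:
- Compound 1 `CC(C)OC(=O)c1ccc(NCc2cncn2Cc2ccc(-c3ccccc3)cc2)cc1-c1ccccc1`: in a toxicity assay on NIH3T3 cells (Mus musculus) for cytotoxicity, read by resazurin assay (a higher number here means that more compound is needed for the effect, a lower number that less compound is needed), compound 1 gives > 10000 nM, a limit of the assay.
- Compound 2 `COc1ccc(NCc2cncn2Cc2ccc(-c3ccccc3)cc2N)cc1-c1ccccc1`: in this assay compound 2 gives > 1000 nM, a limit of the assay.
- Compound 3 `Fc1ccc(Cn2cncc2CNc2ccc(-c3nc4ccccc4s3)c(-c3ccccc3)c2)c(F)c1`: in this assay compound 3 gives > 1000 nM, a limit of the assay.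

None of the three measured compounds yields a number in this assay; each sits at a limit. Compound 1 stands at the limit of > 10000 nM in this assay, at which 1 of the 3 values shown sits, while compounds 2 and 3 stand at the limit of > 1000 nM in this assay, at which 2 of the 3 values shown sit. Every value is a limit. Going by the values given here, no step between measured compounds can be computed, and no ordering among them can be read from these data.

The unmeasured compound 4 `c1ccc(-c2ccc(Cn3cncc3CNc3ccc(-c4noc5ccccc45)c(-c4ccccc4)c3)cc2)cc1` differs from compound 1 in one place: a group of 9 heavy atoms (7 carbon, 1 nitrogen, 1 oxygen; one five-membered aromatic ring with 2 hetero atoms, one six-membered aromatic ring of carbon only) in place of a group of 6 heavy atoms (4 carbon, 2 oxygen; no ring), on an aromatic carbon. Among the compounds with values here, since no measured step in this assay is available, the expectation rests on compound 1 standing at the limit of > 10000 nM in this assay, at which 1 of the 3 values shown sits, and on the other two compounds also reporting only limits. Compound 4 is therefore expected to give about 15000 nM, within a range of 5000 nM to 50000 nM, most likely again as a limit rather than a number. The step that the limit leaves unreadable from compound 1 to compound 4 is expected to be none beyond the usual scatter.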

Compound 4, half-maximal effective concentration: > 10000 nM
Compound 4: a limit, no number; the forecaster's own chance of this, stated with the estimate: 80%; the middle value lies beyond the limit too.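

In this assay, compound 1 and compound 4 both report only a limit, so no step can be read between them. The compounds shown leave open what concentration of any of them produces the effect, and whether replacing the isopropoxycarbonyl group changes it.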